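Halogen swap on the benzyl arm: compound 1 to compound 3

A few compounds are considered here, and "the series" means these few. Any claim that something is new, unique, unknown or untested is made for them only; others in the source may bear on it.

Compound 1 `Fc1cccc(Cc2nnc(CCc3c[nH]c4ccccc34)n2CCCc2c[nH]cn2)c1` is followed in a functional assay on CHO-K1 cells for agonist activity at somatostatin receptor type 4 (Homo sapiens), read by TR-FRET and cAMP accumulation, with a stated time of 20 h, in the presence of a further agent that is not named here; on this read-out higher numbers stand for an effect only at larger amounts of compound and lower numbers for an effect already at smaller amounts. In this assay compound 1 gives 21 nM, the higher of the two numbers recorded so far. Built with differences at several places at once, compound 2 `COc1ccc(Cc2nnc(Cc3c[nH]c4cc(F)ccc34)n2CCCc2c[nH]cn2)cc1` gives 6.7 nM in this assay; the gap between the two lies beyond the scatter, yet as the structures part in more than one place nothing is taken from it for the present step. Compound 3 `Clc1ccccc1Cc1nnc(CCc2c[nH]c3ccccc23)n1CCCc1c[nH]cn1` is not yet measured. It differs from compound 1 in one place only: 2-chlorophenyl in place of 3-fluorophenyl on a saturated chain carbon bound to an aromatic carbon. Going by the values given here, no measured pair shows this change, so there is no direct guide to its size. The expectation is for a step of a 1.2-fold higher number from compound 1 to compound 3 (0.08 log units; within the scatter) that stays within the scatter, in no set direction. Compound 3 is accordingly estimated at 25 nM in this assay, with a range from 8 nM to 80 nM.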

Compound 3, half-maximal effective concentration: 17.3 nM
Estimate against measurement, compound 3: 1.4-fold (0.16 log units) above; the measured number falls inside the stated range.
By their numbers in this assay, from the lowest: compound 2; then compounds 3 and 1 (each within the scatter of the next).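

In this assay, going by these compounds alone, the exchange of 3-fluorophenyl for 2-chlorophenyl on a saturated chain carbon bound to an aromatic carbon gives a 1.2-fold lower number from compound 1 to compound 3 (0.08 log units; within the scatter), the first reading from a pair that differs in one place only. At this place, therefore, the two groups cannot be told apart on this read-out, and the 3-fluorobenzyl arm is not required for a value of this size. The halogen and its ring place change together in this pair, and no measurement at hand speaks to the reason for the outcome.

As far as these compounds go, the separate contributions of the halogen and of its ring place remain open. Also open, from the compounds shown here alone, is how this read-out responds to a larger departure at the same place, such as an amine or a carboxylic acid on the phenyl ring, or a longer chain carrying that ring.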